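Aryl swap on a shared core: cytotoxicity working notes

The compounds below may be only part of what the source reports. "The series", "measured", "known", "first", "only" and "open" are said of these compounds alone.

Three compounds in this series are measured. Compound 1 `Cc1cccc(N2CCN(CCCNc3nc(NCc4ccco4)c4ccccc4n3)CC2)c1C` gives 95.9% in a functional assay on MCF7 cells (Homo sapiens) for cytotoxicity, read by MTT assay, with a stated time of 2 days, tested at 10 uM; a lower number here means less inhibition, a higher number more inhibition at the concentration tested (going by the name of the read-out). Compound 2 `Clc1cccc(N2CCN(CCCNc3nc(NCc4ccco4)c4ccccc4n3)CC2)c1Cl` gives 95.9% in this assay, and compound 3 `Clc1cccc(N2CCN(CCCCNc3nc(NCc4ccco4)c4ccccc4n3)CC2)c1Cl` gives 95.8%. The difference between the core of compound 2 and the core of compound 3 is not broken down here. From compound 2 to compound 1 the change is 2,3-dimethylphenyl in place of 2,3-dichlorophenyl on an amine nitrogen in a ring, and the step is no change at the digits printed from compound 2 to compound 1 (within the scatter).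

Compound 4 `Cc1cccc(N2CCN(CCCCNc3nc(NCc4ccco4)c4ccccc4n3)CC2)c1C` is not yet measured. It differs from compound 3 by 2,3-dimethylphenyl in place of 2,3-dichlorophenyl on an amine nitrogen in a ring, the same change at the same place as between compound 2 and compound 1. The step from compound 3 to compound 4 is expected to be a number 0.3 percentage points lower from compound 3 to compound 4 (within the scatter) because the matching step no change at the digits printed from compound 2 to compound 1 (within the scatter) was flat. Compound 4 is therefore expected to give 95.5% in this assay, with a range from 89% to 99%.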

Compound 4, a percentage reported as inhibition, at one concentration (the size of the read-out at that concentration, not a potency): 95.8%
Beside the measured number, compound 4's estimate is 0.3 percentage points below it; measured number inside the range.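

The swap of 2,3-dichlorophenyl for 2,3-dimethylphenyl on an amine nitrogen in a ring gives no change at the digits printed from compound 3 to compound 4 (within the scatter) in this assay, and the two cores agree: the same change on two cores in this assay, no change at the digits printed (within the scatter) from compound 2 to compound 1 and no change at the digits printed (within the scatter) from compound 3 to compound 4, 0 percentage points apart, within the scatter of two such steps. On these two pairs, the change carries from one core to the other with no visible difference in this read-out. The read-out gives the size of inhibition at one concentration and not a potency, so the flat steps do not show that the two aryl groups are equivalent in potency, or that the change stays flat on any other core.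

Left open is how the series reads with an unsubstituted phenyl or a pyridine on that amine nitrogen, or with a longer chain. Also open, on these data alone, is whether any of these groups would separate at a lower concentration.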